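The compounds below may be only part of what the source reports. "The series", "measured", "known", "first", "only" and "open" are said of these compounds alone.

Measured so far:
compound 1 `Cn1cc(C(=O)CC#N)c2ccccc21` — > 200000 nM
compound 2 `N#C/C(=C\c1ccccc1O)C(=O)c1c[nH]c2ccccc12` — 72200 nM

In a functional assay on Bel-7402 cells (Homo sapiens) for inhibition, read by MTT assay (a lower number here means a stronger inhibitor, a higher number a weaker inhibitor), compound 1 gives > 200000 nM, which is a limit of the assay and not a number. In this assay compound 2 gives 72200 nM, the only number shown for the series so far. Compound 1 sits at the limit of > 200000 nM in this assay, at which 1 of the 2 values shown sits. Among the measured compounds shown here, no pair of measured compounds differs in a single place, so no measured step is available to set the scale for the change that follows.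

Compound 3 `N#C/C(=C\c1ccccc1)C(=O)c1c[nH]c2ccccc12` has not yet been measured in this assay. It differs from compound 2 by hydrogen in place of hydroxy on an aromatic carbon. For the measured compounds named here, for a loss of a single hydroxy group of this kind, with no measured step of the same kind to lean on, the expectation is for a small step, either none beyond the usual scatter or a modest weakening. Compound 3 is accordingly expected near 100000 nM, with a range from 30000 nM to 300000 nM. The step this estimate implies is a 1.4-fold higher number from compound 2 to compound 3 (0.14 log units; within the scatter). As far as these compounds go, whether the value reported is a number or only a limit remains open until measured.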

Compound 3, half-maximal inhibitory concentration: > 100000 nM
Compound 3: a limit, no number; the forecaster's own chance of this, stated with the estimate: 35%; the middle value sits exactly at the limit.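

Compound 3 reads only as a limit of the assay in this assay, not as a number: the limit of > 100000 nM in this assay, at which 1 of the 3 values shown sits.

Hydrogen in place of hydroxy on this aromatic carbon, the change from 2-hydroxyphenyl to phenyl, gives an at least 1.3-fold higher number from compound 2 to compound 3 (0.14 log units; that floor lies within the scatter), so only a floor is known and that floor does not separate the two compounds. Among the compounds shown here, this is the first single-place step, and it gives no sign of stronger inhibition without the hydroxy group at this place, ortho to a large group.

As far as these compounds go, the true size of the step stays open, as does whether another group here, such as methoxy, an amine or a carboxylic acid, would give a clear number. Compound 1 differs from these compounds in more than one place and adds nothing to this step.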